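Extending an Ether Chain in Two Related Cores

This account rests on a few compounds, and the source may have more. Where it says the series, first, only, none or still open, it means among the compounds named here.

Compound 1 `CCOCc1cc(O)c(O)c(Br)c1Br`: 2510 nM
Compound 2 `CCCOCc1cc(O)c(O)c(Br)c1Br`: 1320 nM
Compound 3 `CCOCc1cc(Br)c(O)c(O)c1Br`: 1540 nM

All three were tested in a functional assay on HCT-116 cells (Homo sapiens) for cytotoxicity, read by MTT assay, with a stated time of 96 h; a lower number here means a stronger inhibitor, a higher number a weaker inhibitor. Compound 1 and compound 2 share one core and differ only by methyl in place of hydrogen on a saturated chain carbon, two bonds along the chain from an oxygen on a saturated carbon, which gave a step of a 1.9-fold lower number from compound 1 to compound 2 (0.28 log units; within the scatter). Compound 3 contains the same atoms as compound 1 joined differently; the difference between the two cores is not broken down here. Compound 4 `CCCOCc1cc(Br)c(O)c(O)c1Br` has not yet been measured and differs from compound 3 by methyl in place of hydrogen on a saturated chain carbon, two bonds along the chain from an oxygen on a saturated carbon, the same change seen between compound 1 and compound 2. For the measured compounds named here, with only that single measured example to draw on, the expectation for compound 4 in this assay rests on it alone. Compound 4 is expected to give about 900 nM. The expected step, a 1.7-fold lower number from compound 3 to compound 4 (0.23 log units; within the scatter), mirrors the earlier one because the measured step was a 1.9-fold lower number from compound 1 to compound 2 (0.28 log units; within the scatter). A range from 450 nM to 1800 nM is expected.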

Compound 4, half-maximal inhibitory concentration: 800 nM
Estimate against measurement, compound 4: 1.1-fold (0.05 log units) above; measured number inside the range.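

In this assay, the change from ethoxy to propoxy on the core of compound 3 gives a 1.9-fold lower number from compound 3 to compound 4 (0.28 log units; within the scatter). Set beside the earlier step on the core of compound 1, the change reads the same on both cores: the same change on two cores in this assay, a 1.9-fold lower number (0.28 log units; within the scatter) from compound 1 to compound 2 and a 1.9-fold lower number (0.28 log units; within the scatter) from compound 3 to compound 4, 1.0-fold (0.01 log units) apart, within the scatter of two such steps. This shows that the two cores agree, but each step on its own lies within the scatter, so it does not show that propoxy really differs from ethoxy on either core, and two cores cannot speak for the rest of the series.

The compounds shown leave open whether a longer chain, such as butoxy, would give a step beyond the scatter. They also leave open what an amine in place of the ether oxygen would do.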